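The source may hold more compounds than are shown below. What is called first, only, known or untested is meant among the compounds shown, and "the series" means these compounds.

In an ADME assay on MT4 cells (Homo sapiens) for cytotoxicity, read by MTT assay (on this read-out lower numbers stand for higher toxicity in this test and higher numbers for lower toxicity in this test), compound 3 (`Cc1cc(C)cc(S(=O)(=O)c2c(C(=O)NC(C)C(=O)NCc3ccccc3O)[nH]c3ccc(Cl)cc23)c1`) gives 14400 nM and compound 1 (`Cc1cc(C)cc(S(=O)(=O)c2c(C(=O)NC(C)c3cccc(O)c3)[nH]c3ccc(Cl)cc23)c1`) gives 16000 nM so the two stand level within the scatter. Compound 2 (`Cc1cc(C)cc(S(=O)(=O)c2c(C(=O)NCC(=O)NCc3ccccc3O)[nH]c3ccc(Cl)cc23)c1`) gives > 47300 nM as a limit of the assay. The step of an at least 3.2-fold lower number from compound 2 to compound 3 (0.51 log units; beyond the scatter) is methyl in place of hydrogen and sits at a different place from the change now in view. For the measured compounds named here, compound 4 (`Cc1cc(C)cc(S(=O)(=O)c2c(C(=O)NC(C)C(=O)NCc3cccc(O)c3)[nH]c3ccc(Cl)cc23)c1`) has the same atoms as compound 3, joined differently (3-hydroxyphenyl in place of 2-hydroxyphenyl on a saturated chain carbon bound to an amide-type nitrogen) and no measured step makes this exchange. The 3-hydroxyphenyl group already appears in the pair behind the nearest step (a 1.1-fold lower number from compound 1 to compound 3 (0.05 log units; within the scatter)) so no shift beyond the scatter is expected in this assay here. The estimated step is a 1.0-fold higher number from compound 3 to compound 4 (0.02 log units; within the scatter) and no more than that is expected. For compound 4 the estimated value is 15000 nM with an expected range from 7000 nM to 35000 nM on this read-out.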

Compound 4, half-maximal cytotoxic concentration: 23800 nM
The estimate for compound 4 lay 1.6-fold (0.20 log units) below the measured number; measured number inside the range.
By their numbers in this assay, from the lowest: compounds 3, 1 and 4 (each within the scatter of the next). At a limit, above all of these: compound 2.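

In this assay, 3-hydroxyphenyl in place of 2-hydroxyphenyl on a saturated chain carbon bound to an amide-type nitrogen gives a 1.7-fold higher number from compound 3 to compound 4 (0.22 log units; within the scatter) and so shows no readable effect of this exchange. The (3-hydroxybenzyl)carbamoyl group in place of 3-hydroxyphenyl gives a 1.5-fold higher number from compound 1 to compound 4 (0.17 log units; within the scatter) and likewise shows no readable change. Nothing shown bears on a cause for these two steps.

Open, from the compounds shown here alone, is whether a carboxylic acid or an amine in place of the hydroxyl on the 3-hydroxybenzyl group would leave the number level. Also open, going by these compounds, is whether hydrogen in place of the chain methyl of compound 4 would shift the number as far as it does between compound 3 and compound 2.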